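A few compounds are considered here, and "the series" means these few. Any claim that something is new, unique, unknown or untested is made for them only; others in the source may bear on it.

Going by the values given here, compound 3 `O=C(Nc1ccc(Cl)cc1)C1CCCN(C(=O)c2cccc(-c3nccs3)c2)C1` stands highest of the three compounds measured so far in an ADME assay on PC-3 cells (Homo sapiens) for cytotoxicity, read by WST assay, tested at 100 uM; a higher number here means more inhibition at the concentration tested (going by the name of the read-out), a lower number less inhibition: compound 3 gives 32%, while compound 1 `Cc1cccc(C(=O)N2CCCC(C(=O)Nc3ccc(Cl)cc3)C2)c1` gives 0% and compound 2 `N#Cc1cccc(C(=O)N2CCCC(C(=O)Nc3ccc(Cl)cc3)C2)c1` gives 0%. Compound 4 `CS(=O)(=O)Nc1cccc(C(=O)N2CCCC(C(=O)Nc3ccc(Cl)cc3)C2)c1` has not yet been measured; it differs from compound 3 as follows: methanesulfonamido in place of 1,3-thiazol-2-yl on an aromatic carbon. Among the compounds with values here, the steps that bear on this change are the two that lead into compound 3: a number 32 percentage points higher from compound 1 to compound 3 (beyond the scatter) and a number 32 percentage points higher from compound 2 to compound 3 (beyond the scatter), both of which show the 1,3-thiazol-2-yl group accompanying the large number, whereas methyl and cyano accompany no inhibition. Since methanesulfonamido, like those two groups, carries no ring, a drop back toward the lower numbers is expected for compound 4, and the expected step is a number 27 percentage points lower from compound 3 to compound 4 (beyond the scatter). Compound 4 is accordingly estimated at 5%, within a range of 0% to 25%.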

Compound 4, a percentage reported as inhibition, at one concentration (the size of the read-out at that concentration, not a potency): 3%
Estimate against measurement, compound 4: 2 percentage points above, and the stated range covers the measured number.
By their numbers in this assay, from the lowest: compounds 1, 2 and 4 (each within the scatter of the next); then compound 3.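

In this assay, methanesulfonamido in place of 1,3-thiazol-2-yl on this aromatic carbon gives a number 29 percentage points lower from compound 3 to compound 4 (beyond the scatter), and the new group falls in with the earlier ones: a number 3 percentage points higher from compound 2 to compound 4 (within the scatter) and a number 3 percentage points higher from compound 1 to compound 4 (within the scatter). A third group with no ring, this one with a hydrogen-bond donor, thus joins methyl and cyano, leaving compound 3 alone with the higher number. Nothing available explains this difference.

Among the compounds shown, the only ring at this place is 1,3-thiazol-2-yl. A phenyl, pyridyl or oxazolyl group here would show whether any ring goes with the higher number, or only this one.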